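The source may hold more compounds than are shown below. What is called first, only, known or untested is meant among the compounds shown, and "the series" means these compounds.

Working notes on the series.

Three members of this set have been measured in a functional assay on cells (Cancer cell lines, Homo sapiens) for cytotoxicity, read by sulforhodamine B assay, with a stated time of 48 h; a higher number here means a weaker inhibitor of growth, a lower number a stronger inhibitor of growth. Compound 1 `COc1ccc(C2=NN(C3=NC(=O)/C(=C4\C(=O)Nc5ccc(Br)cc54)S3)C(c3ccc(OC)cc3)C2)cc1` gives 200 nM. Compound 2 `COc1ccc(C2=NN(C3=NC(=O)/C(=C4\C(=O)Nc5ccc(Cl)cc54)S3)C(c3ccc(OC)cc3)C2)cc1` gives 210 nM. Compound 3 `CN(C)c1ccc(C2CC(c3ccccc3)=NN2C2=NC(=O)/C(=C3\C(=O)Nc4ccc(Br)cc43)S2)cc1` gives 200 nM. Compound 1 and compound 2 share a core and differ in a single place: chloro in place of bromo on an aromatic carbon. That exchange produced a 1.1-fold higher number from compound 1 to compound 2 (0.02 log units; within the scatter). Compound 3 carries a different core from compound 1; the difference between the two cores is not broken down here, and the two values sit level with each other at the digits recorded, within the scatter.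

Compound 4 `CN(C)c1ccc(C2CC(c3ccccc3)=NN2C2=NC(=O)/C(=C3\C(=O)Nc4ccc(Cl)cc43)S2)cc1` is not yet measured in this assay. Against compound 3 it differs in one place: chloro in place of bromo on an aromatic carbon. This is the same change that turned compound 1 into compound 2, made on the same position of the same kind of ring. The step of a 1.1-fold higher number from compound 3 to compound 4 (0.02 log units; within the scatter) is expected to be small, because a 1.1-fold higher number from compound 1 to compound 2 (0.02 log units; within the scatter) stayed within the scatter. Compound 4 is accordingly estimated at 210 nM in this assay, with a plausible range from 120 nM to 380 nM. The measured value follows.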

Compound 4, concentration for 50% growth inhibition: 190 nM
Estimate against measurement, compound 4: 1.1-fold (0.04 log units) above, within the range that was stated.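

In this assay, among the compounds shown here, chloro in place of bromo on the core of compound 3 gives a 1.1-fold lower number from compound 3 to compound 4 (0.02 log units; within the scatter), so this exchange produces no step that stands out from the scatter on this core. Set beside the earlier step, the result on the two cores agrees: the same change on two cores in this assay, a 1.1-fold higher number (0.02 log units; within the scatter) from compound 1 to compound 2 and a 1.1-fold lower number (0.02 log units; within the scatter) from compound 3 to compound 4, 1.1-fold (0.04 log units) apart, within the scatter of two such steps

This shows that, on these two cores, bromo and chloro on this aromatic carbon cannot be told apart in this read-out, but it does not show that other changes would carry from one core to the other, and two pairs with steps this small cannot test whether a change with a clear effect would transfer in the same way.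

The compounds shown hold only bromo or chloro on that aromatic carbon, which leaves open what a methyl, a nitrile or a carboxylic acid there would do. Also open, on these data alone, is the effect of replacing the dimethylamino group of compound 3 with a morpholine or a simple amine as a single change.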